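The source may hold more compounds than are shown below. What is called first, only, known or untested is meant among the compounds shown, and "the series" means these compounds.

Measured compounds:
- compound 3 `C#CCSc1nc(Sc2nccs2)c(C#N)c(-c2ccc(C)cc2)n1`: 2200 nM
- compound 2 `C#CCSc1nc(Sc2nccs2)c(C#N)c(-c2ccc(Cl)cc2)n1`: 3230 nM
- compound 1 `C#CCSc1nc(Sc2nccs2)c(C#N)c(-c2ccc(Br)cc2)n1`: 11600 nM

In a functional assay on MCF7 cells (Homo sapiens) for antiproliferative activity, read by MTT assay, with a stated time of 72 h (a lower number here means a stronger inhibitor, a higher number a weaker inhibitor), compound 3 gives the lowest of the three numbers, but only the gap to compound 1 is beyond the scatter: a 5.3-fold lower number from compound 1 to compound 3 (0.72 log units; beyond the scatter). Against compound 2 the difference is a 1.5-fold lower number from compound 2 to compound 3 (0.17 log units; within the scatter), within the scatter, so compound 2 and compound 3 cannot be ordered. The remaining step, a 3.6-fold lower number from compound 1 to compound 2 (0.56 log units; beyond the scatter), is modest.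

Compound 4 `C#CCSc1nc(Sc2nccs2)c(C#N)c(-c2ccc[nH]2)n1` differs from compound 3 as follows: 1H-pyrrol-2-yl in place of 4-methylphenyl on an aromatic carbon.

All three measured steps exchange one substituent on the six-membered aromatic ring of carbon only while that ring stays; none replaces the ring itself with a five-membered aromatic ring carrying a nitrogen and a hydrogen-bond donor. Within the data shown here, no measured step therefore bears directly on this change. From the compounds shown here alone, the measured steps are all modest or within the scatter, which suggests the shared core tolerates variation at this position without large swings, but the direction for compound 4 is unknown. The expectation is therefore a step of no more than modest size in this assay, with wide uncertainty, and the estimate for compound 4 is 4500 nM, range 1200 nM to 18000 nM, i.e. an expected step of a 2.0-fold higher number from compound 3 to compound 4 (0.31 log units; beyond the scatter).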

Compound 4, half-maximal inhibitory concentration: > 20000 nM
Compound 4: no number, only a limit; the forecaster's own chance of this, stated with the estimate: 10%; middle value at least 4.4-fold (0.64 log units) from the limit.
By their numbers in this assay, from the lowest: compounds 3 and 2 (each within the scatter of the next); then compound 1. At a limit, above all of these: compound 4.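

Compound 4 in this assay carries a limit, not a number: the limit of > 20000 nM in this assay, at which 1 of the 4 values shown sits. Replacing the aryl group with 1H-pyrrol-2-yl gives an at least 9.0-fold higher number from compound 3 to compound 4 (0.95 log units; beyond the scatter) and an at least 6.1-fold higher number from compound 2 to compound 4 (0.79 log units; beyond the scatter), so this position, which gave modest steps or steps within the scatter while the six-membered aromatic ring of carbon only stayed, does not accept every exchange of the ring itself in this assay. Against the bromo compound the result is less firm, with an at least 1.7-fold higher number from compound 1 to compound 4 (0.23 log units; that floor lies within the scatter), so compound 4 is not clearly separated from compound 1 on these data.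

The single change alters ring size, brings in a ring nitrogen and adds a hydrogen-bond donor, and the compounds shown do not tell these apart. From the compounds shown here alone, a furan ring, a thiophene ring, a pyrrole ring with methyl on its nitrogen or a pyridine ring at this position would be needed to separate them, and how far compound 4 lies beyond its limit remains unknown.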